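Aryl swaps on the amine nitrogen: cytotoxicity notes

This account rests on a few compounds, and the source may have more. Where it says the series, first, only, none or still open, it means among the compounds named here.

Measured in a functional assay on HT-29 cells (Homo sapiens) for cytotoxicity, read by sulforhodamine B assay (a higher number here means a weaker inhibitor, a lower number a stronger inhibitor), as follows
- compound 1 `C=C1[C@@H](OC(C)=O)C[C@@H]2[C@](C)(CO[Si](C)(C)C(C)(C)C)[C@H](OC(C)=O)CC[C@@]2(C)[C@@H]1C[C@@H](Nc1cccc(F)c1)C1=CCOC1=O` gives 4520 nM
- compound 2 `C=C1[C@@H](OC(C)=O)C[C@@H]2[C@](C)(CO[Si](C)(C)C(C)(C)C)[C@H](OC(C)=O)CC[C@@]2(C)[C@@H]1C[C@@H](Nc1ccccc1)C1=CCOC1=O` gives 4050 nM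
- compound 3 `C=C1[C@@H](OC(C)=O)C[C@@H]2[C@](C)(CO[Si](C)(C)C(C)(C)C)[C@H](OC(C)=O)CC[C@@]2(C)[C@@H]1C[C@@H](Nc1ccc(OC)cc1)C1=CCOC1=O` gives 5370 nM

Compound 3 (5370 nM) lies within the scatter of both other compounds. Compound 4 `C=C1[C@@H](OC(C)=O)C[C@@H]2[C@](C)(CO[Si](C)(C)C(C)(C)C)[C@H](OC(C)=O)CC[C@@]2(C)[C@@H]1C[C@@H](Nc1cccc2ccccc12)C1=CCOC1=O` carries naphthalen-1-yl in place of 4-methoxyphenyl on an amine nitrogen. The measured steps, a 1.1-fold lower number from compound 1 to compound 2 (0.05 log units; within the scatter) and a 1.2-fold higher number from compound 1 to compound 3 (0.07 log units; within the scatter) and a 1.3-fold higher number from compound 2 to compound 3 (0.12 log units; within the scatter), all stay within the scatter. Going by these compounds, none of them introduces a second aromatic ring, so this change is untested. In this assay the expected result is no shift beyond the scatter, with a 1.2-fold lower number from compound 3 to compound 4 (0.08 log units; within the scatter) as the estimated step. For compound 4 the estimated value is 4500 nM (expected range 2200 nM to 9000 nM).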

Compound 4, half-maximal inhibitory concentration: 15000 nM
Compound 4: the middle estimate sits 3.3-fold (0.52 log units) below what was measured, outside the stated range (above it).
By their numbers in this assay, from the lowest: compounds 2, 1 and 3 (each within the scatter of the next); then compound 4.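

In this assay the aryl group on the amine nitrogen does matter: naphthalen-1-yl gives a 2.8-fold higher number from compound 3 to compound 4 (0.45 log units; beyond the scatter) and a 3.7-fold higher number from compound 2 to compound 4 (0.57 log units; beyond the scatter) and a 3.3-fold higher number from compound 1 to compound 4 (0.52 log units; beyond the scatter) as its steps, each towards a weaker inhibitor. Compounds 1, 2 and 3, each with one aromatic ring at this position, stay within the scatter of one another, while compound 4, with two, stands apart from all three. Nothing available accounts for this shift. Going by these compounds, whether the second ring or its naphthalen-1-yl attachment drives the loss stays open. Naphthalen-2-yl, benzyl or cyclohexyl on the same nitrogen would help separate these readings.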